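The compounds below may be only part of what the source reports. "The series", "measured", "known", "first", "only" and "open" are said of these compounds alone.

Compound 2 `CNc1nc(NCc2ccc(Cl)cc2)cc(-c2ccccn2)n1` gives the lowest number of the three measured compounds in a functional assay on HEK293 cells for agonist activity at G-protein coupled receptor 39 (Homo sapiens), read by inositol phosphate accumulation (on this read-out higher numbers stand for an effect only at larger amounts of compound and lower numbers for an effect already at smaller amounts), at 15 nM. Compound 3 `CNC(=O)c1ccc(CNc2cc(-c3ccccn3)nc(NC)n2)cc1` sits close by with 30 nM, and the step of a 2.0-fold higher number from compound 2 to compound 3 (0.30 log units; within the scatter) is within the scatter. Compound 1 `COCCNc1nc(NCC2CC2)cc(-c2ccccn2)n1` lies far off with 2200 nM. Compound 4 `CNc1nc(NCC2CC2)cc(-c2ccccn2)n1` differs from compound 2 in one place: cyclopropyl in place of 4-chlorophenyl on a saturated chain carbon bound to a nitrogen on an aromatic ring. Among the measured compounds shown here, the only measured step at this position, from compound 2 to compound 3, swapped one substituent on the phenyl ring and left the number unchanged; no measured step removes the ring itself. Compound 1, which also carries cyclopropyl but differs at the other amine as well, gives a far higher number, so some loss is expected. The estimate for compound 4 is 300 nM, between 60 nM and 1500 nM, a step of a 20-fold higher number from compound 2 to compound 4 (1.30 log units; beyond the scatter).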

Compound 4, half-maximal effective concentration: 164 nM
Estimate against measurement, compound 4: 1.8-fold (0.26 log units) above, within the range that was stated.
By their numbers in this assay, from the lowest: compounds 2 and 3 (each within the scatter of the next); then compound 4; then compound 1.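

Changing the ring itself, and not only its substituent, proves to matter at this position: in this assay cyclopropyl in place of 4-chlorophenyl gives an 11-fold higher number from compound 2 to compound 4 (1.04 log units; beyond the scatter) while the earlier swap on the phenyl ring stayed within the scatter. With cyclopropyl held fixed, the other amine also counts, since hydrogen in place of methoxymethyl gives a 13-fold lower number from compound 1 to compound 4 (1.13 log units; beyond the scatter) on that chain carbon. Going by these compounds, whether a cyclohexyl ring, a longer chain or an amine in place of cyclopropyl would bring the number back down remains open, as does the effect of methoxymethyl alongside 4-chlorophenyl. Nothing available explains either step.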